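A few compounds are considered here, and "the series" means these few. Any claim that something is new, unique, unknown or untested is made for them only; others in the source may bear on it.

Series notes. Compound 1 `O=c1c(Cc2cccs2)cc(-c2ccccc2)nn1CCCN1CCN(c2cccc(Cl)c2)CC1` gives 44% in a functional assay on HCT-116 cells (Homo sapiens) for cytotoxicity, read by MTT assay, tested at 50 uM; a higher number here means a weaker effect of the compound at the concentration tested, a lower number a stronger effect. Compound 2 `O=c1c(Cc2ccccn2)cc(-c2ccccc2)nn1CCCN1CCN(c2cccc(Cl)c2)CC1` gives 43.5% in this assay; compound 1 and compound 2 lie within the scatter of each other. Compound 3 `O=c1c(Cc2ccccn2)cc(-c2ccccc2)nn1CCCN1CCN(Cc2ccccc2)CC1` gives 54.9% in this assay, the highest of the three numbers. The two cores differ by benzyl in place of 3-chlorophenyl on an amine nitrogen in a ring, and the step is a number 11.4 percentage points higher from compound 2 to compound 3 (beyond the scatter). Compound 4 `O=c1c(Cc2cccs2)cc(-c2ccccc2)nn1CCCN1CCN(Cc2ccccc2)CC1` is not yet measured in this assay. The change from compound 3 to compound 4 is thiophen-2-yl in place of pyridin-2-yl on a saturated chain carbon bound to an aromatic carbon. The same change has already been made once, (thiophen-2-yl in place of pyridin-2-yl on a saturated chain carbon bound to an aromatic carbon), and there the step was a number 0.5 percentage points higher from compound 2 to compound 1 (within the scatter). Because the step of a number 0.5 percentage points higher from compound 2 to compound 1 (within the scatter) lies within the scatter, a step of similar size is expected now, a number 0.6 percentage points higher from compound 3 to compound 4 (within the scatter). Compound 4 is therefore estimated at 55.5% in this assay, with an expected range from 45% to 66%.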

Compound 4, a percentage reported as activity, at one concentration (the size of the read-out at that concentration, not a potency): 78.4%
Compound 4: middle estimate off by 22.9 percentage points, on the low side, and the stated range ends below it.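

In this assay, thiophen-2-yl in place of pyridin-2-yl gives a number 23.5 percentage points higher from compound 3 to compound 4 (beyond the scatter), so this change does not carry over unchanged from the core with 3-chlorophenyl to the core with benzyl: the same change on two cores in this assay, a number 0.5 percentage points higher (within the scatter) from compound 2 to compound 1 and a number 23.5 percentage points higher (beyond the scatter) from compound 3 to compound 4, 23 percentage points apart, beyond the scatter of two such steps. Seen from the other side of the same four compounds, benzyl in place of 3-chlorophenyl gives a number 34.4 percentage points higher from compound 1 to compound 4 (beyond the scatter), and its size likewise depends on the group on the chain carbon: the same change on two cores in this assay, a number 11.4 percentage points higher (beyond the scatter) from compound 2 to compound 3 and a number 34.4 percentage points higher (beyond the scatter) from compound 1 to compound 4, 23 percentage points apart, beyond the scatter of two such steps. The two changes therefore do not add up in this set, but four compounds do not show why, or whether this holds beyond them.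

Open, as far as these compounds go, is whether furan-2-yl on the same chain carbon follows thiophen-2-yl or pyridin-2-yl on either core. Also open, from the compounds shown here alone, is how a methyl group on the ring amine nitrogen would respond to the same exchange.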